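The source may report more compounds than this note shows. Statements on the series, on what has been measured and on what is new or still open speak of the compounds shown alone.

In a functional assay on MCF7 cells (Homo sapiens) for cytotoxicity, read by CellTiter-Glo, with a stated time of 5 days (a higher number here means a weaker inhibitor, a lower number a stronger inhibitor), compound 1 `C/C(=C(/c1ccc(/C=C/C(=O)O)cc1)c1ccc2[nH]ncc2c1)c1ccccc1` gives 40 nM, and compound 2 `CC/C(=C(/c1ccc(/C=C/C(=O)O)cc1)c1ccc2[nH]ncc2c1)c1ccccc1` gives 7.2 nM. Among the compounds with values here, the single step measured so far, a 5.6-fold lower number from compound 1 to compound 2 (0.74 log units; beyond the scatter), comes from the change that lengthens the saturated chain on the shared core from a methyl to an ethyl group. Within the data shown here, compound 2 therefore holds the lowest of the two numbers so far, with compound 1 the only neighbour, a clearly higher number beyond the scatter.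

Compound 3 `COCC/C(=C(/c1ccc(/C=C/C(=O)O)cc1)c1ccc2[nH]ncc2c1)c1ccccc1` carries the change (methoxy in place of hydrogen on a saturated chain carbon, two bonds along the chain from a double-bonded chain carbon). Among the measured compounds shown here, the only step that bears on it is a 5.6-fold lower number from compound 1 to compound 2 (0.74 log units; beyond the scatter), which showed that growing the saturated chain by one carbon was rewarded with a modest drop. For the measured compounds named here, the new change grows the chain again, but this time the group that enters carries an oxygen, and there is no measured pair that tells how an oxygen-bearing extension fares. Going by the values given here, the expectation is thus a step of a 1.4-fold lower number from compound 2 to compound 3 (0.16 log units; within the scatter), at most a small further lowering or nothing beyond the scatter, with the ethyl-to-methyl comparison as the only guide. On that basis compound 3 is expected to give about 5 nM in this assay, with a range from 1.5 nM to 18 nM.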

Compound 3, half-maximal inhibitory concentration: 63 nM
Beside the measured number, compound 3's estimate is 13-fold (1.10 log units) below it; the whole stated range lies below it.
By their numbers in this assay, from the lowest: compound 2; then compounds 1 and 3 (each within the scatter of the next).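

In this assay, growth of the saturated chain on the shared core is not rewarded without limit: methoxy in place of hydrogen on a saturated chain carbon, two bonds along the chain from a double-bonded chain carbon, brings an 8.8-fold higher number from compound 2 to compound 3 (0.94 log units; beyond the scatter) and so takes away the gain that the ethyl group had given. Measured against the methyl starting point, the 2-methoxyethyl group shows a 1.6-fold higher number from compound 1 to compound 3 (0.20 log units; within the scatter) and thus offers no advantage over methyl. Of the three chains shown, ethyl alone stands apart, with steps beyond the scatter to both methyl and 2-methoxyethyl, so the earlier drop did not carry over to this oxygen-bearing extension. No measurement here accounts for this reversal.

The compounds shown leave open whether the rise follows the added length or the oxygen, a question that a plain propyl or butyl chain in the same place would bear on. They also leave open how a hydroxyl group, an amine or a small ring such as cyclopropyl would fare on this chain.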